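Swapping the amino-phenyl ketone of compound 2 for a dichlorophenyl

This account rests on a few compounds, and the source may have more. Where it says the series, first, only, none or still open, it means among the compounds named here.

Of the compounds shown here, two sharing one core have been tested in a functional assay on SNB-19 cells (Homo sapiens) for inhibition, read by sulforhodamine B assay, with a stated time of 48 h; a lower number here means a stronger inhibitor of growth, a higher number a weaker inhibitor of growth. Compound 1 `COc1ccc(-c2cc(/C=C/C(=O)c3ccc(N)cc3)[nH]n2)cc1` gives 2290 nM. Compound 2 `COc1cc(-c2cc(/C=C/C(=O)c3ccc(N)cc3)[nH]n2)cc(OC)c1OC` gives 2340 nM, and the two numbers lie within the usual scatter of each other, so neither stands apart from the other. Compound 3 `COc1cc(-c2cc(/C=C/C(=O)c3ccc(Cl)c(Cl)c3)[nH]n2)cc(OC)c1OC` is not yet measured. It differs from compound 2 in one place: 3,4-dichlorophenyl in place of 4-aminophenyl on a carbonyl carbon. Among the compounds with values here, no pair among the measured compounds shows what this change does, and the two values that exist give no hint of how a group on the carbonyl carbon matters. Without such a step, the expected change in this assay from compound 2 to compound 3 is none beyond the scatter, and the estimated step is a 1.3-fold lower number from compound 2 to compound 3 (0.11 log units; within the scatter). For compound 3 the expected value in this assay is 1800 nM, with a range from 500 nM to 6500 nM.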

Compound 3, concentration for 50% growth inhibition: 9830 nM
The estimate for compound 3 lay 5.5-fold (0.74 log units) below the measured number; measured number above the stated range.
By their numbers in this assay, from the lowest: compounds 1 and 2 (each within the scatter of the next); then compound 3.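

In this assay, the group on the carbonyl carbon clearly matters: 3,4-dichlorophenyl in place of 4-aminophenyl gives a 4.2-fold higher number from compound 2 to compound 3 (0.62 log units; beyond the scatter), a loss of growth inhibition that compound 1 and compound 2 could not reveal, as both carry 4-aminophenyl. The group that leaves has a hydrogen-bond donor and acceptor, whereas the group that enters has neither and brings chlorine, but this single step cannot separate those differences. Nothing at hand gives a measured reason for the step.

Going by these compounds, it remains open whether the loss comes from removing the amine or from adding chlorine, which a plain phenyl or a 4-chlorophenyl on the same carbonyl carbon could help to separate. On these data alone, it is also open whether the same change would have a similar effect on the core of compound 1.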